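Trading Two Chlorines for a Chlorine and a Methyl

The source may report more compounds than this note shows. Statements on the series, on what has been measured and on what is new or still open speak of the compounds shown alone.

Of the compounds shown here, three have been tested in a functional assay on HEK293 cells for agonist activity at D(4) dopamine receptor (Homo sapiens), read by FLIPR; a lower number here means a smaller maximal response, a higher number a larger maximal response. Compound 1 `O=C(NCN1CCC(c2cccc[n+]2[O-])CC1)c1cnccc1Cl` gives 44%, compound 2 `Cc1cccc(NC(=O)CN2CCC(c3ccccc3)CC2)c1` gives 37%, and compound 3 `O=C(CN1CCC(c2cccc[n+]2[O-])CC1)Nc1cc(Cl)cc(Cl)c1` gives 68%. Compound 3 stands highest of the three; its nearest neighbour is compound 1, and compound 2 lies further still, both gaps reaching beyond the scatter of repeated measurements. Compound 4 `Cc1ccc(Cl)cc1NC(=O)CN1CCC(c2cccc[n+]2[O-])CC1` has not yet been measured. It differs from compound 3 in one place: 5-chloro-2-methylphenyl in place of 3,5-dichlorophenyl on an amide-type nitrogen Nothing else in the molecule is altered. Within the data shown here, no pair among the measured compounds differs in a single place, so no measured step can be carried over directly. Among the measured compounds shown here, compound 2 is the only measured compound that also carries a methyl, and in this assay it gives only 37%. On that basis a fall in response is expected. The expected step is a number 16 percentage points lower from compound 3 to compound 4 (beyond the scatter), a modest one. The estimate for compound 4 in this assay is 52%, within 32% to 72%.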

Compound 4, largest response reached (reported as efficacy), in percent of the reference or control that the assay uses: 58%
Estimate against measurement, compound 4: 6 percentage points below; low and high end bracket the measured number.
By their numbers in this assay, from the lowest: compounds 2 and 1 (each within the scatter of the next); then compounds 4 and 3 (each within the scatter of the next).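

In this assay, replacing 3,5-dichlorophenyl with 5-chloro-2-methylphenyl on the amide-type nitrogen gives a number 10 percentage points lower from compound 3 to compound 4 (within the scatter). Among these compounds, this is the first step here that changes a single place, and it shows that compound 3 and compound 4 cannot be told apart in maximal response: at this position, a ring with one chlorine and a methyl serves as well as the ring with two chlorines, at least for this pair. No measured property of either group bears on this result, so the step stays a plain observation.

The compounds shown leave open how a methoxy group or a nitrile would fare on this aromatic ring. Also unresolved is whether the same swap would behave alike on a different core, such as that of compound 2.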